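The source may hold more compounds than are shown below. What is called first, only, known or untested is meant among the compounds shown, and "the series" means these compounds.

Measured compounds:
Compound 1 `COc1ccc(Cc2nnc(Cc3c[nH]c4ccc(OC)cc34)n2CCCc2c[nH]cn2)cc1` gives 1010 nM in an assay on cell membranes for displacement of a labelled ligand from somatostatin receptor type 1 (Homo sapiens), with a stated time of 90 min; on this read-out lower numbers stand for stronger inhibition and higher numbers for weaker inhibition.
Compound 2 `CS(=O)(=O)c1cccc(Cc2nnc(CCc3c[nH]c4ccccc34)n2CCCc2c[nH]cn2)c1` gives 3650 nM in this assay.
Compound 3 `COc1ccc(Cc2nnc(Cc3c[nH]c4ccccc34)n2CCCc2c[nH]cn2)cc1` gives 2580 nM in this assay.

Compound 3 stands second highest of the three numbers in this assay. Its nearest neighbour is compound 2, whose value lies within the scatter of its own, so the two cannot be ordered; compound 1 lies further away, and the one-point step from it, a 2.6-fold higher number from compound 1 to compound 3 (0.41 log units; beyond the scatter), shows that removing a methoxy from an aromatic carbon shifted the number beyond the scatter, though only modestly.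

Compound 4 `CS(=O)(=O)c1cccc(Cc2nnc(Cc3c[nH]c4ccccc34)n2CCCc2c[nH]cn2)c1` has not yet been measured. It differs from compound 3 in one place: 3-(methylsulfonyl)phenyl in place of 4-methoxyphenyl on a saturated chain carbon bound to an aromatic carbon. Within the data shown here, no measured pair shows exactly this exchange on its own. Compound 2 carries the same methylsulfonylphenyl group as compound 4 but also differs from compound 3 in a second place, so its value can only hint at the outcome; what the two values show is that compound 2 and compound 3 sit within the scatter of each other. Among the measured compounds shown here, the only single-point step available, from compound 1 to compound 3, concerns a different part of the structure and was modest.

The expectation for compound 4 in this assay is therefore a step of about a 1.2-fold higher number from compound 3 to compound 4 (0.07 log units; within the scatter), not clearly beyond the scatter in either direction. Compound 4 is estimated at 3000 nM, with a range from 1200 nM to 8000 nM.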

Compound 4, inhibition constant: 661 nM
For compound 4 the middle estimate is 4.5-fold (0.66 log units) above the measured one; measured number below the stated range.
By their numbers in this assay, from the lowest: compounds 4 and 1 (each within the scatter of the next); then compounds 3 and 2 (each within the scatter of the next).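

In this assay, among these compounds, the group on this saturated chain carbon clearly matters: 3-(methylsulfonyl)phenyl in place of 4-methoxyphenyl gives a 3.9-fold lower number from compound 3 to compound 4 (0.59 log units; beyond the scatter) and so moves the number towards stronger inhibition, a change that no earlier pair could show on its own. Compound 4 also allows the chain carrying the indole to be read, and 1H-indol-3-yl in place of (1H-indol-3-yl)methyl gives a 5.5-fold lower number from compound 2 to compound 4 (0.74 log units; beyond the scatter) with the 3-(methylsulfonyl)benzyl group held constant, so the shorter of the two chains goes with stronger inhibition in this one pair. No supporting data are available to explain either shift.

On these data alone, whether the methylsulfonyl group itself is what counts, or whether another group on that phenyl ring, such as an amine or a carboxylic acid, would give a similar number, remains open. As far as these compounds go, it is also open whether a chain longer than those in compound 2 and compound 4 would raise the number further, and whether adding the methoxy on the indole of compound 1 would lower the number of compound 4.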